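Notes on compound 2 and a hexyl analogue

The compounds below may be only part of what the source reports. "The series", "measured", "known", "first", "only" and "open" are said of these compounds alone.

Three compounds sharing one core have numbers in a functional assay on PC-3 cells (Homo sapiens) for cytotoxicity, read by MTT assay, with a stated time of 72 h; on this read-out lower numbers stand for stronger inhibition and higher numbers for weaker inhibition. Compound 1 `O=[N+]([O-])c1cccc(COCNc2n[n+]([O-])c3ccccc3[n+]2[O-])c1` gives only a limit there, > 100000 nM. Compound 2 `[O-][n+]1nc(NCOCc2ccc(Cl)cc2)[n+]([O-])c2ccccc21` gives 5100 nM, the lowest of the two numbers shown. Compound 3 `CC(OCNc1n[n+]([O-])c2ccccc2[n+]1[O-])c1ccccc1` gives 10700 nM, and its gap from compound 2 lies beyond the usual scatter. Compound 4 `CCCCCCCOCNc1n[n+]([O-])c2ccccc2[n+]1[O-]` has not been measured yet. It differs from compound 2 as follows: hexyl in place of 4-chlorophenyl on a saturated chain carbon bound to an oxygen on a saturated carbon. Going by the values given here, no measured pair shows this change, so the size of the step is open; a modest rise in the number, or none beyond the scatter, is expected. For compound 4 the estimate in this assay is 12000 nM, with a range from 3000 nM to 50000 nM. This estimate means an expected step of a 2.4-fold higher number from compound 2 to compound 4 (0.37 log units; beyond the scatter).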

Compound 4, half-maximal inhibitory concentration: 390 nM
Estimate against measurement, compound 4: 31-fold (1.49 log units) above; the whole stated range lies above it.
By their numbers in this assay, from the lowest: compound 4; then compound 2; then compound 3. At a limit, above all of these: compound 1.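

In this assay, hexyl in place of 4-chlorophenyl on a saturated chain carbon bound to an oxygen on a saturated carbon gives a 13-fold lower number from compound 2 to compound 4 (1.12 log units; beyond the scatter). The earlier compounds shown here all carry an aromatic ring in this part of the molecule, so only this result shows that a chain without a ring can go with a far lower number. Nothing available here accounts for the size of this step.

As far as these compounds go, whether a longer chain, a shorter chain or an amine in this place would hold the number this low remains open. One pair cannot show how the number follows chain length.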